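This account rests on a few compounds, and the source may have more. Where it says the series, first, only, none or still open, it means among the compounds named here.

Among the compounds with values here, compound 2 `CCC(CC)Nc1nc2cc(-c3ccc(C)cc3)sc2c(=O)[nH]1` holds the only number measured in an ADME assay on HepG2 cells (Homo sapiens) for cytotoxicity, read by MTT assay, with a stated time of 72 h; on this read-out higher numbers stand for lower toxicity in this test and lower numbers for higher toxicity in this test: compound 2 gives 101000 nM. Compound 1 `CCCNc1nc2cc(-c3ccc(C)cc3)sc2c(=O)[nH]1` is its nearest neighbour among the measured compounds. In this assay compound 1 gives only a limit, > 62500 nM. Because of the limit of > 62500 nM in this assay, at which 1 of the 2 values shown sits, the step that the limit leaves unreadable from compound 1 to compound 2 cannot be read in size or direction.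

Compound 3 `CCCCCCC(C)Nc1nc2cc(-c3ccc(C)cc3)sc2c(=O)[nH]1` is not yet measured. The change from compound 2 is 1-methylheptyl in place of pentan-3-yl on a nitrogen on an aromatic ring. Within the data shown here, no measured step bears on this change. The single step shown is unreadable, so there is no foothold for expecting movement one way or the other. The expectation for compound 3 in this assay is therefore no step beyond the usual scatter, with a wide range on either side. Compound 3 is expected to give about 90000 nM, between 30000 nM and 200000 nM. The step of a 1.1-fold lower number from compound 2 to compound 3 (0.05 log units; within the scatter) is expected to be small.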

Compound 3, half-maximal cytotoxic concentration: 19400 nM
Estimate against measurement, compound 3: 4.6-fold (0.67 log units) above, and the stated range ends above it.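

In this assay, within the data shown here, the substituent on this nitrogen does matter: 1-methylheptyl in place of pentan-3-yl gives a 5.2-fold lower number from compound 2 to compound 3 (0.72 log units; beyond the scatter), the first step here whose size can be read. A lower number means higher toxicity in this test, so the chain of 8 carbon atoms is the more toxic of the two. 1-Methylheptyl in place of propyl points the same way, with an at least 3.2-fold lower number from compound 1 to compound 3 (0.50 log units; beyond the scatter), but this size is only a lower bound because of a limit: the limit of > 62500 nM in this assay, at which 1 of the 3 values shown sits.

The step from compound 1 to compound 2 cannot be read, so it remains unclear whether the number falls steadily as the chain grows or whether the shape of the chain also counts. From the compounds shown here alone, how a still longer chain, or an amine at the end of the chain, would behave also remains open.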